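The compounds below may be only part of what the source reports. "The series", "measured", "known", "first", "only" and "open" are said of these compounds alone.

In an ADME assay on microsomes from liver (Homo sapiens) for metabolic stability (a higher number here means faster removal of the compound, a lower number slower removal), compound 3 `CCC(Oc1ccc(-n2cc(C(F)(F)F)cn2)cc1)c1ccc(C(=O)NCCC(=O)O)cc1` gives only a limit, < 8 mL/min/kg, not a number. Compound 1 `O=C(O)CCNC(=O)c1ccc(C(Oc2ccc(-n3cc(C(F)(F)F)cn3)cc2)C2CC2)cc1` also gives a limit, < 8 mL/min/kg. Compound 2 `CCCC(Oc1ccc(-n2cc(C(=O)N(C)C)cn2)cc1)c1ccc(C(=O)NCCC(=O)O)cc1` gives a limit as well, < 13 mL/min/kg. The lower of these is shared: the limit of < 8 mL/min/kg in this assay, at which 2 of the 3 values shown sit. Compound 4 `CC(C)(C)C(Oc1ccc(-n2cc(C(F)(F)F)cn2)cc1)c1ccc(C(=O)NCCC(=O)O)cc1` has one change from compound 3: tert-butyl in place of ethyl on a saturated chain carbon bound to an aromatic carbon and an oxygen on an aromatic ring. For the measured compounds named here, the one measured step at this carbon is a step that the two limits leave unreadable from compound 1 to compound 3, with ethyl in place of cyclopropyl, so it offers no size to carry over, and no change beyond the scatter is expected in this assay. The expected step is a step that the limit leaves unreadable from compound 3 to compound 4. For compound 4 the estimate is 7 mL/min/kg, with an expected range from 3 mL/min/kg to 14 mL/min/kg.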

Compound 4, clearance: 31 mL/min/kg
For compound 4 the middle estimate is 4.4-fold (0.65 log units) below the measured one; the measured number lies above the stated range.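

In this assay the group on this saturated chain carbon can matter: tert-butyl in place of ethyl gives an at least 3.8-fold higher number from compound 3 to compound 4 (0.58 log units; beyond the scatter) and tert-butyl in place of cyclopropyl gives an at least 3.8-fold higher number from compound 1 to compound 4 (0.58 log units; beyond the scatter). Ethyl and cyclopropyl could not show this, as the step between them cannot be read. Both new sizes are only minimum sizes, since compound 1 and compound 3 are each known only as a limit: the limit of < 8 mL/min/kg in this assay, at which 2 of the 4 values shown sit. From the compounds shown here alone, what isopropyl or a phenyl ring would give at this carbon remains open. So does how far removal changes between ethyl and tert-butyl.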